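Methyl Added to the Side Chain: Estimating Compound 4

The compounds below may be only part of what the source reports. "The series", "measured", "known", "first", "only" and "open" are said of these compounds alone.

Of the compounds shown here, three built on one shared core have been tested in a functional assay on MCF7 cells (Homo sapiens) for antiproliferative activity; a lower number here means a stronger inhibitor, a higher number a weaker inhibitor. Compound 1 `CCNCCCOc1ccc2cc(NC(=O)c3ccc(O)c(CC=C(C)C)c3)c(=O)oc2c1C` gives 980 nM. Compound 2 `CC(C)=CCc1cc(C(=O)Nc2cc3ccc(OCCCNC(C)C)c(C)c3oc2=O)ccc1O` gives 740 nM in this assay, and compound 3 `CC(C)=CCc1cc(C(=O)Nc2cc3ccc(OCCCNCc4ccccc4)c(C)c3oc2=O)ccc1O` gives 910 nM. The change from compound 1 to compound 2 is methyl in place of hydrogen on a saturated chain carbon bound to an amine nitrogen and a saturated chain carbon, and it produced a 1.3-fold lower number from compound 1 to compound 2 (0.12 log units; within the scatter). Compound 3 differs from compound 1 in the amine side chain, with a step of a 1.1-fold lower number from compound 1 to compound 3 (0.03 log units; within the scatter), and from compound 2 by a 1.2-fold higher number from compound 2 to compound 3 (0.09 log units; within the scatter). All three numbers thus sit within the usual scatter of one another.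

Compound 4 `CC(C)=CCc1cc(C(=O)Nc2cc3ccc(OCCCN[C@H](C)c4ccccc4)c(C)c3oc2=O)ccc1O` has not yet been measured. It differs from compound 3 by methyl in place of hydrogen on a saturated chain carbon bound to an amine nitrogen and an aromatic carbon. Among the measured compounds shown here, this is the same kind of change as the one from compound 1 to compound 2, not the same one: in compound 2 the carbon carrying the new methyl is bound to an amine nitrogen and a saturated chain carbon, whereas in compound 4 it is bound to an amine nitrogen and an aromatic carbon. The two starting compounds also differ from each other, compound 3 from compound 1 by phenyl in place of methyl on a saturated chain carbon bound to an amine nitrogen.

For compound 4 the expected step is a 1.1-fold lower number from compound 3 to compound 4 (0.06 log units; within the scatter), because the earlier step was a 1.3-fold lower number from compound 1 to compound 2 (0.12 log units; within the scatter) and the surroundings of the change are only modestly different. Compound 4 is therefore estimated at 800 nM in this assay, most likely falling between 400 nM and 1600 nM.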

Compound 4, half-maximal inhibitory concentration: 1450 nM
Estimate against measurement, compound 4: 1.8-fold (0.26 log units) below, within the range that was stated.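

In this assay, adding the methyl to the carbon bound to an amine nitrogen and an aromatic carbon gives a 1.6-fold higher number from compound 3 to compound 4 (0.20 log units; within the scatter), and setting this beside the earlier step shows no real difference between the two cores: the same change on two cores in this assay, a 1.3-fold lower number (0.12 log units; within the scatter) from compound 1 to compound 2 and a 1.6-fold higher number (0.20 log units; within the scatter) from compound 3 to compound 4, 2.1-fold (0.32 log units) apart, within the scatter of two such steps

The other two new comparisons, a 2.0-fold higher number from compound 2 to compound 4 (0.29 log units; within the scatter) and a 1.5-fold higher number from compound 1 to compound 4 (0.17 log units; within the scatter), also stay within the scatter, so the numbers of all four compounds still cannot be told apart. This means there is no sign that the methyl behaves differently on the two cores, but it does not prove that its effect carries over from one to the other, since each step is small enough to be ordinary variation between repeated measurements and the opposite directions of the two steps cannot be taken at face value.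

Going by these compounds, what remains open is whether any group on this carbon can move the number beyond the scatter, for example an ethyl or a cyclopropyl in place of the methyl. Also open, on these data alone, is whether a different group on the amine nitrogen, such as cyclohexylmethyl, would give a clearer reading of the same methyl change.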